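The compounds below may be only part of what the source reports. "The series", "measured", "known", "first", "only" and "open" are said of these compounds alone.

Measured in a functional assay on SK-OV-3 cells (Homo sapiens) for antiproliferative activity, read by MTT assay, with a stated time of 72 h; on this read-out lower numbers stand for stronger inhibition and higher numbers for weaker inhibition:
- compound 1 `COc1ccccc1NC(=O)CCc1cccc2c1B(O)OC2`: 200 nM
- compound 2 `C#Cc1ccccc1NC(=O)CCc1cccc2c1B(O)OC2`: 820 nM

Compound 2, at 820 nM, holds the higher of the two numbers and so is the weaker inhibitor of this pair in this assay. The next compound, compound 3 `O=C(CCc1cccc2c1B(O)OC2)Nc1ccccc1-c1ccccc1`, keeps everything else in compound 2 and alters a single group: phenyl in place of ethynyl on an aromatic carbon.

Going by the values given here, only one measured step bears on this change, and it concerns the same place: a 4.1-fold higher number from compound 1 to compound 2 (0.61 log units; beyond the scatter). That modest step shows that the read-out responds to the group at this place. Among the compounds with values here, no measured compound carries phenyl there, however, so the evidence for size and direction is thin. Within the data shown here, the one known step went upward, and a similar modest size is the most the data suggest, so a slight lean upward is expected, with no step clearly beyond the scatter. The expected step is a 1.5-fold higher number from compound 2 to compound 3 (0.17 log units; within the scatter). For compound 3 the estimated value is 1200 nM, within an expected range of 300 nM to 4500 nM.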

Compound 3, half-maximal inhibitory concentration: 26000 nM
Compound 3: middle estimate off by 22-fold (1.34 log units), on the low side; measured number above the stated range.
By their numbers in this assay, from the lowest: compound 1; then compound 2; then compound 3.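

In this assay, phenyl on the aromatic carbon ortho to a large group gives a 32-fold higher number from compound 2 to compound 3 (1.50 log units; beyond the scatter) when it replaces ethynyl, and a 130-fold higher number from compound 1 to compound 3 (2.11 log units; beyond the scatter) when it replaces methoxy. The earlier step, a 4.1-fold higher number from compound 1 to compound 2 (0.61 log units; beyond the scatter), showed only that this place responds modestly to a change of group, whereas these results show that a single substitution here can weaken inhibition by a far larger margin, and they place the three groups in the order methoxy, ethynyl, phenyl, with every step beyond the scatter. Nothing measured here accounts for the large rise in the number with phenyl.

With only three groups compared, the compounds shown cannot tell whether the rise follows the aromatic ring or the larger count of heavy atoms, a question that a cyclohexyl group at the same place could help to separate. They also leave open whether a small group such as fluorine, or an amine or a carboxylic acid, would keep the number near that of compound 1 or take it lower.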